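This account rests on a few compounds, and the source may have more. Where it says the series, first, only, none or still open, it means among the compounds named here.

Compound 1 `COc1ccc(/C=N/NC(=S)NC(C)(C)[C@H]2CC=C(C)CC2)cc1` in a functional assay on MCF7 cells (Homo sapiens) for inhibition, read by sulforhodamine B assay, with a stated time of 48 h (a higher number here means a weaker inhibitor of growth, a lower number a stronger inhibitor of growth), gives 31200 nM. Compound 2 `CC1=CC[C@H](C(C)(C)NC(=S)N/N=C/c2ccc(O)cc2)CC1` in this assay reaches only a limit, > 100000 nM. Among the measured compounds shown here, the single change between them, hydrogen in place of methyl on an oxygen on an aromatic ring, goes with an at least 3.2-fold higher number from compound 1 to compound 2 (0.50 log units; beyond the scatter), a size bounded by the limit of > 100000 nM in this assay, at which 1 of the 2 values shown sits. Compound 3 `CC1=CC[C@H](C(C)(C)NC(=S)N/N=C/c2ccc(F)cc2)CC1` differs from compound 2 by fluoro in place of hydroxy on an aromatic carbon. For the measured compounds named here, only that one measured step bears on this change, and it was at least modest; removal of the hydroxy is therefore expected to move the number back down. The step from compound 2 to compound 3 is expected to be an at least 3.3-fold lower number from compound 2 to compound 3 (0.52 log units; beyond the scatter). Compound 3 is estimated at 30000 nM, within 10000 nM to 100000 nM.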

Compound 3, concentration for 50% growth inhibition: > 100000 nM
Compound 3: only a limit was reported; the forecaster's own chance of this, stated with the estimate: 25%; middle value at least 3.3-fold (0.52 log units) from the limit.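

On this aromatic carbon, para to a large group, fluoro in place of methoxy gives an at least 3.2-fold higher number from compound 1 to compound 3 (0.50 log units; beyond the scatter) in this assay, so hydroxy is no longer the only replacement of methoxy that goes with weaker growth inhibition. Compound 2 and compound 3 both sit at a limit, so the step between them cannot be read: the limit of > 100000 nM in this assay, at which 2 of the 3 values shown sit.

From the compounds shown here alone, whether hydroxy and fluoro differ at all stays open, as does how far either lies from methoxy. Also open, going by these compounds, is whether an ethoxy, an amine or a chloro group here would hold the level of compound 1 or improve on it.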